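Methoxy for hydroxy on the shared core of compounds 3 and 4

The compounds below may be only part of what the source reports. "The series", "measured", "known", "first", "only" and "open" are said of these compounds alone.

Compound 1 `COC(=O)CN(C)Cc1c(OC)cc(OC)c(C(=O)/C=C/c2ccccc2Cl)c1O` and compound 2 `COc1cc(OC)c(C(=O)/C=C/c2ccccc2Cl)c(O)c1CN(C)CC(=O)O` share one core; compound 3 `COc1cc(O)c2c(=O)cc(-c3ccccc3Cl)oc2c1CN1CCCCC1` and compound 4 `COc1cc(OC)c2c(=O)cc(-c3ccccc3Cl)oc2c1CN1CCCCC1` share another. In a functional assay on A549 cells (Homo sapiens) for antiproliferative activity, with a stated time of 72 h (a lower number here means a stronger inhibitor, a higher number a weaker inhibitor), compound 1 gives 9100 nM, compound 2 gives 79400 nM, and compound 3 gives 45500 nM. The difference between the two cores is not broken down here.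

From compound 2 to compound 1 the change is methyl in place of hydrogen on an oxygen next to a carbonyl group, and it brings an 8.7-fold lower number from compound 2 to compound 1 (0.94 log units; beyond the scatter). From compound 3 to compound 4 the change is methyl in place of hydrogen on an oxygen on an aromatic ring. Both are methyl in place of hydrogen on an oxygen, so the same kind of change, but not the same: in the first the oxygen is next to a carbonyl group whose other neighbour is a carbonyl carbon, in the second it is on an aromatic ring whose other neighbour is an aromatic carbon. For the measured compounds named here, the only measured instance rests on compound 2 and compound 1, and it belongs to a different place and a different core, so its size is no firm guide.

The step from compound 3 to compound 4 in this assay is expected to be smaller than the measured one, around a 1.8-fold lower number from compound 3 to compound 4 (0.26 log units; within the scatter), because of the direction of an 8.7-fold lower number from compound 2 to compound 1 (0.94 log units; beyond the scatter) only. Compound 4 is therefore estimated at 25000 nM, between 8000 nM and 80000 nM.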

Compound 4, half-maximal inhibitory concentration: > 150000 nM
Compound 4: only a limit was reported (the forecaster's own chance of this, stated with the estimate: 15%); at least 6.0-fold (0.77 log units) between middle value and limit.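

In this assay compound 4 gives > 150000 nM, which is a limit of the assay and not a number. Methyl in place of hydrogen on an oxygen on an aromatic ring brings an at least 3.2-fold higher number from compound 3 to compound 4 (0.51 log units; beyond the scatter), so the direction seen on the other core does not carry over to this one: the same change on two cores in this assay, an 8.7-fold lower number (0.94 log units; beyond the scatter) from compound 2 to compound 1 and an at least 3.2-fold higher number (0.51 log units; beyond the scatter) from compound 3 to compound 4, at least 28-fold (1.45 log units) apart, beyond the scatter of two such steps The two instances differ both in core and in the place of the oxygen, and these compounds do not separate the two, so the result shows no rule for either and the full size of the step on the core of compound 3 stays unknown.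

Open, as far as these compounds go, is how the same oxygen would respond to the same change on each of the two cores, which would tell core from place. Also open, from the compounds shown here alone, is whether a longer chain on that oxygen of the core of compound 3, such as ethyl in place of methyl, follows compound 4 or compound 3.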